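Side-chain swaps at the fluoromethyl position of compound 1

The source may report more compounds than this note shows. Statements on the series, on what has been measured and on what is new or still open speak of the compounds shown alone.

Measured in a functional assay on MCF7 cells (Homo sapiens) for antiproliferative activity, read by MTT assay, with a stated time of 48 h; on this read-out higher numbers stand for weaker inhibition and lower numbers for stronger inhibition:
- compound 1 `CC(C)=CCC[C@]1(C)/C=C/[C@@H](OC(=O)C=C(C)C)[C@](C)(O)/C=C/C(=O)/C(CF)=C\C1`: 240 nM
- compound 2 `CC(C)=CCC[C@]1(C)/C=C/[C@@H](OC(=O)C=C(C)C)[C@](C)(O)/C=C/C(=O)/C(CN(C)C)=C\C1`: 690 nM
- compound 3 `COCOC/C1=C/C[C@](C)(CCC=C(C)C)/C=C/[C@@H](OC(=O)C=C(C)C)[C@](C)(O)/C=C/C1=O`: 3120 nM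

Compound 1 gives the lowest number of the three, and both steps away from it lie beyond the scatter, so within this set it is the most potent in this assay. Putting dimethylamino in place of fluoro costs a 2.9-fold higher number from compound 1 to compound 2 (0.46 log units; beyond the scatter); putting methoxymethoxy there costs a 13-fold higher number from compound 1 to compound 3 (1.11 log units; beyond the scatter); between the two replacement groups the step is a 4.5-fold higher number from compound 2 to compound 3 (0.66 log units; beyond the scatter). Every group so far brought into this position in place of fluoro has raised the number, and the one with more atoms raised it more.

Compound 4 `CC(C)=CCC[C@]1(C)/C=C/[C@@H](OC(=O)C=C(C)C)[C@](C)(O)/C=C/C(=O)/C(Cn2cc(CO)nn2)=C\C1` carries the change (4-(hydroxymethyl)-1H-1,2,3-triazol-1-yl in place of fluoro on a saturated chain carbon bound to a double-bonded ring carbon). Both measured steps from compound 1 bear on it, as both swap the fluoro at the same place for a larger, heteroatom-bearing group: the modest 2.9-fold higher number from compound 1 to compound 2 (0.46 log units; beyond the scatter) and the large 13-fold higher number from compound 1 to compound 3 (1.11 log units; beyond the scatter). The entering group here brings in more heavy atoms than either dimethylamino or methoxymethoxy. A large upward step in this assay is therefore expected for compound 4, of about a 13-fold higher number from compound 1 to compound 4 (1.10 log units; beyond the scatter). The estimate for compound 4 is 3000 nM, with a range from 800 nM to 12000 nM.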

Compound 4, half-maximal inhibitory concentration: 2930 nM
For compound 4 the middle estimate is 1.0-fold (0.01 log units) above the measured one; low and high end bracket the measured number.
By their numbers in this assay, from the lowest: compound 1; then compound 2; then compounds 4 and 3 (each within the scatter of the next).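

In this assay, a ring at this place is tolerated no better than the open-chain methoxymethoxy group: the 4-(hydroxymethyl)-1H-1,2,3-triazol-1-yl group in place of fluoro gives a large loss (a 12-fold higher number from compound 1 to compound 4 (1.09 log units; beyond the scatter)), which confirms that all three replacements tested on this saturated chain carbon lose potency against fluoro, leaving compound 1 the most potent of the four. The earlier link between more atoms in the entering group and a higher number does not continue, since the triazolyl group has the most heavy atoms of the set yet its step from methoxymethoxy stays within the scatter (a 1.1-fold lower number from compound 3 to compound 4 (0.03 log units; within the scatter)), and compound 4 goes against that pattern, while dimethylamino keeps a clear advantage over the triazolyl group (a 4.2-fold higher number from compound 2 to compound 4 (0.63 log units; beyond the scatter)). No supporting data accompany these values, so the differences between the groups remain unexplained here.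

The compounds shown leave open whether the loss depends on the hydroxymethyl group on the triazole ring, which a triazole carrying a plain methyl group or a carboxylic acid at that place would test. They also leave open how a small group such as chloro or hydroxy at this place compares with fluoro, and whether a primary amine or a longer chain ending in dimethylamino would hold the potency of compound 2.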